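A few compounds are considered here, and "the series" means these few. Any claim that something is new, unique, unknown or untested is made for them only; others in the source may bear on it.

Compound 1 `COc1ccc(/C=N/NC(=O)Nc2ccc(Oc3ccnc(-c4nncn4CCN(C)C)c3)c(F)c2)c(OC)c1` and compound 2 `COc1cc(/C=N/NC(=O)Nc2ccc(Oc3ccnc(-c4nncn4CCN(C)C)c3)c(F)c2)ccc1O` share one core and differ only in the aryl group attached to the carbon with a double bond to nitrogen. In a functional assay on A549 cells (Homo sapiens) for cytotoxicity, read by MTT assay, with a stated time of 72 h (on this read-out lower numbers stand for stronger inhibition and higher numbers for weaker inhibition), compound 1 gives 2820 nM. Compound 2 reaches only a limit of the assay in this assay, namely > 100000 nM; this is the limit described by the limit of > 100000 nM in this assay, at which 1 of the 2 values shown sits. The step of an at least 35-fold higher number from compound 1 to compound 2 (1.54 log units; beyond the scatter) is therefore the only comparison shown, and it places compound 2 at the weak end of what is seen.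

Compound 3 `CN(C)CCn1cnnc1-c1cc(Oc2ccc(NC(=O)N/N=C/c3cccc(O)c3)cc2F)ccn1` carries the change (3-hydroxyphenyl in place of 4-hydroxy-3-methoxyphenyl on a carbon with a double bond to nitrogen). Among the compounds with values here, no measured step covers this exact exchange; the single known step shows that the aryl group on this carbon matters greatly, but its direction for the 3-hydroxyphenyl group is not told by the data. Compound 3 is therefore expected to sit near compound 2, the step of an at least 2.5-fold lower number from compound 2 to compound 3 (0.39 log units; beyond the scatter) being small, with an estimate of 40000 nM and a range from 6000 nM to 200000 nM.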

Compound 3, half-maximal inhibitory concentration: > 100000 nM
Compound 3: no number, only a limit; the forecaster's own chance of this, stated with the estimate: 45%; at least 2.5-fold (0.39 log units) between middle value and limit.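

In this assay compound 3 also gives only a limit, > 100000 nM. The 3-hydroxyphenyl group on this carbon thus falls well short of the 2,4-dimethoxyphenyl group, with an at least 35-fold higher number from compound 1 to compound 3 (1.54 log units; beyond the scatter). Among these three compounds, both aryl groups that carry a hydroxy group end at the same limit, and the step between those two compounds cannot be read, so the methoxy group of compound 2 shows no readable effect: the limit of > 100000 nM in this assay, at which 2 of the 3 values shown sit.

On these data alone, what remains open is whether the hydroxy group itself weakens the compounds, or whether compound 1 owes its stronger inhibition to its two methoxy groups. A plain phenyl group or a 4-methoxyphenyl group on this carbon would help to separate these two readings.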